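The compounds below may be only part of what the source reports. "The series", "measured", "known", "first", "only" and "open" are said of these compounds alone.

Working notes on the series, all read in a functional assay on HL-60 cells (Homo sapiens) for cytotoxicity, read by MTT assay, with a stated time of 48 h; a lower number here means a stronger inhibitor, a higher number a weaker inhibitor. Of the compounds shown here, three have numbers so far. Compound 1 (`COc1ccc2[nH]c(-c3ccccc3F)cc(=O)c2c1O`) gives 70 nM, and compound 2 (`O=c1cc(-c2ccc(F)cc2)[nH]c2ccc(O)c(O)c12`) gives 38600 nM. Compound 3 (`COc1cc2c(=O)cc(-c3ccccc3F)[nH]c2cc1O`) gives 1300 nM, the middle of the three numbers, with compound 1 lower and compound 2 higher, both gaps beyond the scatter. No two of these compounds differ in one place only, so no measured step bears directly on the next change.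

Compound 4 (`COc1cc2c(=O)cc(-c3cccc(F)c3)[nH]c2cc1O`) has 3-fluorophenyl in place of 2-fluorophenyl on an aromatic carbon, next to the ring nitrogen of the shared core (3-fluorophenyl in place of 2-fluorophenyl on an aromatic carbon). Without a matched pair, no step beyond the scatter is expected in this assay, and no direction is favoured. The anchor is compound 3 at 1300 nM, but the spread of the three values argues for a wide range. The estimated step is a 1.1-fold lower number from compound 3 to compound 4 (0.03 log units; within the scatter). For compound 4 the estimated value is 1200 nM, with an expected range of 250 nM to 6000 nM.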

Compound 4, half-maximal inhibitory concentration: 900 nM
Estimate against measurement, compound 4: 1.3-fold (0.12 log units) above; measured number inside the range.
By their numbers in this assay, from the lowest: compound 1; then compounds 4 and 3 (each within the scatter of the next); then compound 2.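

For the compounds shown here, this is the first matched pair. In this assay, 3-fluorophenyl in place of 2-fluorophenyl on the aromatic carbon next to the ring nitrogen gives a 1.4-fold lower number from compound 3 to compound 4 (0.16 log units; within the scatter), so this read-out does not separate the two fluorophenyl groups at this position on the shared core. Nothing on hand explains why the two read alike.

Still open, as far as these compounds go, is whether a different group on this carbon, such as plain phenyl, a chlorophenyl or a methoxyphenyl, would give a step beyond the scatter. Going by these compounds alone, also open is whether the same change would read alike on the core of compound 1, which gives 70 nM, since no matched pair on that core is available here.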